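The compounds below may be only part of what the source reports. "The series", "measured", "known", "first", "only" and "open" are said of these compounds alone.

Series notes, Substance-K receptor binding.

Compound 1 `O=C(O)CCCCN(Cc1ccccc1)Cc1ccc2ccccc2c1` is the reference for the series. In an assay on HEK293 cells for binding affinity to Substance-K receptor (Rattus norvegicus), read by FRET, tested at 10 uM (a lower number here means less inhibition, a higher number more inhibition at the concentration tested (going by the name of the read-out)), compound 1 gives 0%. Compound 2 `CN1CCN(C(=O)CN(Cc2ccccc2)Cc2ccc3ccccc3c2)CC1` replaces the acid-bearing chain with an amide and in this assay compound 2 gives 0%; the step of no change at the digits printed from compound 1 to compound 2 (within the scatter) is flat. Compound 2 therefore stands level with compound 1, and neither shows inhibition at the concentration tested.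

The next compound, compound 3 `O=C(CN(Cc1ccccc1)Cc1ccc2ccccc2c1)N1CCN(c2ccccc2)CC1`, differs from compound 2 at a single place: phenyl in place of methyl on an amine nitrogen in a ring.

Among the measured compounds shown here, only one measured step exists, no change at the digits printed from compound 1 to compound 2 (within the scatter), and it changes the substituent on the benzylic amine, not the ring nitrogen touched here, so it bears on compound 3 only indirectly: both measured compounds show no inhibition, and the shared core has not yet given any signal. The step from compound 2 to compound 3 is therefore expected to be a number 5 percentage points higher from compound 2 to compound 3 (within the scatter), that is, no change beyond the scatter. For compound 3 the estimate in this assay is 5%, with a range from -5% to 20%.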

Compound 3, a percentage reported as inhibition, at one concentration (the size of the read-out at that concentration, not a potency): 0%
Beside the measured number, compound 3's estimate is 5 percentage points above it; measured number inside the range.
By their numbers in this assay, from the lowest: compounds 1, 2 and 3 (each within the scatter of the next).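

In this assay, putting phenyl in place of methyl on the amine nitrogen in the ring gives no change at the digits printed from compound 2 to compound 3 (within the scatter). Among the compounds shown here, this is the first reading at this position, three ring bonds from the ring nitrogen, and it shows that going from one heavy atom to six, with a six-membered aromatic ring of carbon only, brings no inhibition at the concentration tested, just as the earlier change on the saturated chain carbon brought none. No supporting measurement bears on why this substitution leaves the reading flat.

With compound 2 at 0% and compound 3 at 0%, a single-concentration reading cannot separate the two substituents, so any difference in their affinity remains unresolved. Open too, going by these compounds, is whether a benzyl group or an acetyl group on that ring nitrogen, or an amine or a longer chain elsewhere on the shared core, would give any signal in this assay.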